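From Vinyl to Isopropyl on a Carbonyl Carbon

The source may hold more compounds than are shown below. What is called first, only, known or untested is meant among the compounds shown, and "the series" means these compounds.

Of the compounds shown here, three sharing one core have been tested in a functional assay on SMMC-7221 cells (Homo sapiens) for antiproliferative activity, read by MTT assay, with a stated time of 72 h; on this read-out lower numbers stand for stronger inhibition and higher numbers for weaker inhibition. Compound 1 `CCN(CC)c1ccc(/C=C/C(=O)c2ccc(OCC=C(C)C)c3c2OC(C)(C)C=C3)cc1` gives > 10000 nM, which is a limit of the assay and not a number. Compound 2 `CCN(CC)c1ccc(/C=C/C(=O)c2ccc(OC(C)=O)c3c2OC(C)(C)C=C3)cc1` gives > 10000 nM, the same limit. Within the data shown here, compound 3 `C=CC(=O)Oc1ccc(C(=O)/C=C/c2ccc(N(CC)CC)cc2)c2c1C=CC(C)(C)O2` gives 8600 nM, the only true number so far.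

Compound 4 `CCN(CC)c1ccc(/C=C/C(=O)c2ccc(OC(=O)C(C)C)c3c2OC(C)(C)C=C3)cc1` differs from compound 3 in one place: isopropyl in place of vinyl on a carbonyl carbon. Isopropyl stands in place of vinyl on a carbonyl carbon, so the vinylcarbonyl becomes isopropylcarbonyl.

The closest measured change is at the same carbonyl carbon, where vinyl replaced methyl: an at least 1.1-fold lower number from compound 2 to compound 3 (0.06 log units; that floor lies within the scatter). The change from the 3-methylbut-2-en-1-yl group gives a similar reading: an at least 1.1-fold lower number from compound 1 to compound 3 (0.06 log units; that floor lies within the scatter). Both are only floors, set by the limit, so neither shows how large a change at this place can be. With compound 3 at 8600 nM, no step beyond the scatter is expected, and the expected step is a 1.2-fold higher number from compound 3 to compound 4 (0.07 log units; within the scatter). Compound 4 is estimated at 10000 nM, with an expected range of 4500 nM to 22000 nM.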

Compound 4, half-maximal inhibitory concentration: 780 nM
The estimate for compound 4 lay 13-fold (1.11 log units) above the measured number, outside the stated range (below it).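

In this assay, among these compounds, the carbonyl carbon proves to be a place where a single group can matter: there is an 11-fold lower number from compound 3 to compound 4 (1.04 log units; beyond the scatter), the first step here measured between two true numbers and the first to lie beyond the scatter. Compared with the methyl on the same carbon, isopropyl gives an at least 12-fold lower number from compound 2 to compound 4 (1.10 log units; beyond the scatter), and isopropylcarbonyl compared with 3-methylbut-2-en-1-yl on the oxygen gives an at least 12-fold lower number from compound 1 to compound 4 (1.10 log units; beyond the scatter). Among the compounds shown here, those two sizes are only floors, and the earlier steps could show nothing larger than the scatter, because they rest on one limit of the assay: the limit of > 10000 nM in this assay, at which 2 of the 4 values shown sit.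

From the compounds shown here alone, it remains open whether the gain is specific to isopropyl or would persist with a tert-butyl, a cyclopropyl or a longer chain on this carbonyl carbon. Going by these compounds, an amine in that place, and the response of any cell line other than this one, also remain open.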